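From 3-chlorobenzyl to 3-bromobenzyl: a single halogen exchange

This account rests on a few compounds, and the source may have more. Where it says the series, first, only, none or still open, it means among the compounds named here.

In a functional assay on HepG2 cells (Homo sapiens) for antiproliferative activity, read by MTT assay, with a stated time of 24 h (a higher number here means a weaker inhibitor, a lower number a stronger inhibitor), three compounds sharing one core have been measured. Compound 1 (`COc1cc(OC)c(-c2coc3cc(OCc4ccccc4F)ccc3c2=O)cc1OC`) gives 1280 nM, compound 2 (`COc1cc(OC)c(-c2coc3cc(OCc4ccccc4C(F)(F)F)ccc3c2=O)cc1OC`) gives 6550 nM, and compound 3 (`COc1cc(OC)c(-c2coc3cc(OCc4cccc(Cl)c4)ccc3c2=O)cc1OC`) gives 750 nM. Compound 3 and compound 1 share the low end of this range. The steps read a 1.7-fold lower number from compound 1 to compound 3 (0.23 log units; within the scatter) and an 8.7-fold lower number from compound 2 to compound 3 (0.94 log units; beyond the scatter).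

Compound 4 (`COc1cc(OC)c(-c2coc3cc(OCc4cccc(Br)c4)ccc3c2=O)cc1OC`) has not yet been measured. It differs from its neighbour by bromo in place of chloro on an aromatic carbon, with bromo in place of chloro on an aromatic carbon, meta to a large group. Among the measured compounds shown here, no measured pair makes this exchange. The nearest step that swaps one group on an aromatic carbon is a 5.1-fold higher number from compound 1 to compound 2 (0.71 log units; beyond the scatter), but it is trifluoromethyl in place of fluoro, so it offers only a loose guide.

No step beyond the scatter is therefore expected, and the estimate stays close to compound 3. The expected change is a 1.1-fold lower number from compound 3 to compound 4 (0.03 log units; within the scatter). For compound 4 the estimated value is 700 nM, within an expected range of 320 nM to 1600 nM.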

Compound 4, half-maximal inhibitory concentration: 870 nM
The estimate for compound 4 lay 1.2-fold (0.09 log units) below the measured number; the range from low to high includes it.
By their numbers in this assay, from the lowest: compounds 3, 4 and 1 (each within the scatter of the next); then compound 2.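

In this assay, bromo in place of chloro on an aromatic carbon, meta to a large group, gives a 1.2-fold higher number from compound 3 to compound 4 (0.06 log units; within the scatter) and so leaves the reading unchanged within the scatter; at this position the two halogens cannot be told apart. Compound 4 also stands where compound 3 stands relative to the other two compounds, with a 7.5-fold lower number from compound 2 to compound 4 (0.88 log units; beyond the scatter) and so beyond the scatter, and with a 1.5-fold lower number from compound 1 to compound 4 (0.17 log units; within the scatter) and so within it. No measured evidence on the two halogens is available to explain this result.

The compounds shown leave open whether a methoxy, a nitrile or an amine on this same carbon would read like the two halogens. They also leave open how 3-fluorobenzyl would read, as the fluoro of compound 1 stands in a 2-fluorophenyl group.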